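Aryl swap on the oxazolone carbamoyl series: pyridyl variant

A few compounds are considered here, and "the series" means these few. Any claim that something is new, unique, unknown or untested is made for them only; others in the source may bear on it.

Measured so far:
compound 1 `O=C(NCCCCc1ccccc1)n1cc(-c2ccc(F)cc2)oc1=O`, 185 nM
compound 2 `COc1ccccc1-c1cn(C(=O)NCCCCc2ccccc2)c(=O)o1`, 177 nM

Both compounds share the same core and the same chain on the carbamoyl nitrogen; they differ only in the aryl group on the five-membered ring. In an assay on isolated protein for inhibition of acid ceramidase (Homo sapiens), read by LC-MS, with a stated time of 1 h (on this read-out higher numbers stand for weaker inhibition and lower numbers for stronger inhibition), compound 2 gives 177 nM, and on this read-out compound 2 stands level with compound 1, the step of a 1.0-fold lower number from compound 1 to compound 2 (0.02 log units; within the scatter) being the only one recorded in the set.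

The next compound, compound 3 `O=C(NCCCCc1ccccc1)n1cc(-c2ccccn2)oc1=O`, is not yet measured. Its change against compound 2 is pyridin-2-yl in place of 2-methoxyphenyl on an aromatic carbon. Among the compounds with values here, the one measured step that bears on this position is the aryl exchange from compound 1 to compound 2, which moved the number by a 1.0-fold lower number from compound 1 to compound 2 (0.02 log units; within the scatter); an aryl-for-aryl exchange at this carbon therefore has so far produced no movement beyond the scatter. Because of that step a 1.0-fold lower number from compound 1 to compound 2 (0.02 log units; within the scatter), no step beyond the scatter is expected for compound 3 in this assay, with a slight lean toward a higher number. Compound 3 is estimated at 230 nM, within 90 nM to 600 nM, which means an expected step of a 1.3-fold higher number from compound 2 to compound 3 (0.11 log units; within the scatter).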

Compound 3, half-maximal inhibitory concentration: 25 nM
Compound 3: middle estimate off by 9.2-fold (0.96 log units), on the high side; measured number below the stated range.
By their numbers in this assay, from the lowest: compound 3; then compounds 2 and 1 (each within the scatter of the next).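

Working notes: in this assay, the aromatic carbon next to the ring oxygen proves sensitive to the aryl group after all. Pyridin-2-yl gives a step beyond the scatter against 2-methoxyphenyl (a 7.1-fold lower number from compound 2 to compound 3 (0.85 log units; beyond the scatter)) and a step of similar size against 4-fluorophenyl (a 7.4-fold lower number from compound 1 to compound 3 (0.87 log units; beyond the scatter)), whereas the exchange between those two groups stayed within the scatter (a 1.0-fold lower number from compound 1 to compound 2 (0.02 log units; within the scatter)). Among these three compounds, the lower number therefore goes with the only aryl ring that contains a hetero atom, with no compound here going against that reading, although no measurement bears on the reason for the step.

Three compounds cannot separate the presence of the ring nitrogen from its placement, so pyridin-3-yl, pyridin-4-yl, unsubstituted phenyl and pyrimidin-2-yl at this carbon remain the informative comparisons. From the compounds shown here alone, it also remains open whether the step from pyridin-2-yl carries over when the phenylbutyl chain on the carbamoyl nitrogen gives way to a shorter alkyl chain or a chain ending in an amine.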